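The source may report more compounds than this note shows. Statements on the series, on what has been measured and on what is new or still open speak of the compounds shown alone.

Working notes on the series in a functional assay on RS4-11 cells (Homo sapiens) for inhibition, read by CCK-8 assay, with a stated time of 48 h; on this read-out higher numbers stand for weaker inhibition and lower numbers for stronger inhibition. Three compounds have numbers or limits so far. Compound 1 `O=[N+]([O-])c1ccc(NC(=S)NCCNS(=O)(=O)c2ccc(-c3ccccc3O[C@H]3CC[C@@H](O)CC3)s2)cc1` gives 9400 nM. Compound 3 `COc1ccc(NC(=S)NCCNS(=O)(=O)c2sccc2-c2ccc(C)cc2Oc2ccc(O)c(O)c2)cc1` gives 8300 nM and so holds the lowest of the two numbers, yet its gap to compound 1 lies within the scatter, so the two are read as indistinguishable on this assay. For compound 2 `O=S(=O)(NCCNC(=S)Nc1ccc(Cl)cc1)c1ccc(-c2ccccc2OCc2ccccc2)s1` this assay reports only a limit, > 50000 nM, and that reading is a limit rather than a number (the limit of > 50000 nM in this assay, at which 1 of the 3 values shown sits).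

Compound 4 `Cc1ccc(-c2ccsc2S(=O)(=O)NCCNC(=S)Nc2ccc([N+](=O)[O-])cc2)c(Oc2ccc(O)c(O)c2)c1` is the next compound to be measured. It differs from compound 3 in one place: nitro in place of methoxy on an aromatic carbon. Among the measured compounds shown here, no measured pair in the set differs in exactly this place, so the step has no direct precedent here. Compound 1 carries the (4-nitrophenyl)amino end but differs from compound 3 at several other positions. In this assay compound 1 gives 9400 nM, which is no help in isolating the change.

With nothing to point either way, the expectation for compound 4 is a step of no more than the scatter, a 1.0-fold lower number from compound 3 to compound 4 (0.02 log units; within the scatter). The estimate for compound 4 in this assay is 8000 nM, with a range from 3000 nM to 22000 nM.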

Compound 4, half-maximal inhibitory concentration: 5100 nM
Estimate against measurement, compound 4: 1.6-fold (0.20 log units) above; measured number inside the range.
By their numbers in this assay, from the lowest: compounds 4, 3 and 1 (each within the scatter of the next). At a limit, above all of these: compound 2.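

In this assay the series now has its first step that changes one place only, on an aromatic carbon of the six-membered aromatic ring, para to a large group: nitro in place of methoxy gives a 1.6-fold lower number from compound 3 to compound 4 (0.21 log units; within the scatter) and so leaves the two compounds indistinguishable on this read-out. In this single pair, the 4-methoxyphenyl and 4-nitrophenyl ends cannot be told apart, even though nitro carries more heavy atoms and more hydrogen-bond acceptors than methoxy. Nothing measured in the series speaks to a cause for this step.

From the compounds shown here alone, this one pair is all that covers the position, so it remains open whether an amine, a carboxylic acid or a longer chain there would move the number beyond the scatter, and whether the same exchange would read alike on the core of compound 1. Compound 2 gives > 50000 nM in this assay as a limit and not a number, and since it differs from compound 3 in more than one place, it adds nothing on this position.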